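Fluorine on the pyridine ring of compound 3

The source may hold more compounds than are shown below. What is called first, only, known or untested is meant among the compounds shown, and "the series" means these compounds.

In a functional assay on HEK293 cells for positive allosteric modulation of metabotropic glutamate receptor 5 (Homo sapiens), read by calcium flux (on this read-out higher numbers stand for larger maximal responses and lower numbers for smaller maximal responses), compound 3 `O=C1c2cc(COc3ccccn3)nn2CCN1c1ccc(F)cc1` gives 68%, the second highest of three numbers. Compound 1 `O=C1c2cc(COc3ccccc3F)nn2CCN1c1ccc(F)cc1` gives 66% and compound 2 `O=C1c2cc(COc3cccc(F)c3)nn2CCN1c1ccc(F)cc1` gives 70%. The steps of a number 4 percentage points higher from compound 1 to compound 2 (within the scatter), a number 2 percentage points higher from compound 1 to compound 3 (within the scatter) and a number 2 percentage points lower from compound 2 to compound 3 (within the scatter) all remain within the scatter, so the three aryl groups on the oxygen cannot be told apart by this read-out. Compound 4 `O=C1c2cc(COc3ccc(F)cn3)nn2CCN1c1ccc(F)cc1` carries the change (fluoro in place of hydrogen on an aromatic carbon), which reads pyridin-2-yl to 5-fluoropyridin-2-yl. For the measured compounds named here, no measured pair exchanges hydrogen for fluoro on an aromatic carbon, and the swaps of whole aryl groups left the maximal response flat, so the expected step in this assay is no change at the digits printed from compound 3 to compound 4 (within the scatter), nothing beyond the scatter. Compound 4 is therefore estimated at 68%, within the range 58% to 78%.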

Compound 4, largest response reached (Emax), in percent of the reference or control that the assay uses: 52%
Compound 4: middle estimate off by 16 percentage points, on the high side; measured number below the stated range.
By their numbers in this assay, from the lowest: compound 4; then compounds 1, 3 and 2 (each within the scatter of the next).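

In this assay the group on the oxygen is no longer silent: one fluoro on the pyridin-2-yl ring, two atoms from the ring nitrogen, gives a number 16 percentage points lower from compound 3 to compound 4 (beyond the scatter) while the earlier swaps of whole aryl groups stayed within the scatter. The 5-fluoropyridin-2-yl group also stands apart from both fluorophenyl groups, with a number 18 percentage points lower from compound 2 to compound 4 (beyond the scatter) and a number 14 percentage points lower from compound 1 to compound 4 (beyond the scatter) on the same read-out. Nothing at hand accounts for this drop. From the compounds shown here alone, whether it belongs to fluoro itself or to any group at this place stays open, and chloro or methyl on the same carbon would bear on that.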